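From hydroxy to fluoro on the aromatic ring

A few compounds are considered here, and "the series" means these few. Any claim that something is new, unique, unknown or untested is made for them only; others in the source may bear on it.

Compound 3 (`COC1=C(C)C(=O)/C(=C(O)/C=C/c2ccc(O)cc2)C(=O)C1(C)C`) carries a 4-hydroxyphenyl group on its chain. In a functional assay on HUVEC cells (Homo sapiens) (a lower number here means that less compound is needed, a higher number that more compound is needed for the effect), compound 3 gives < 4 ug/mL as a limit of the assay and not as a number. Two relatives share its core, compound 1 (`COC1=C(C)C(=O)/C(=C(O)/C=C/c2ccc(Br)cc2)C(=O)C1(C)C`) and compound 2 (`COC1=C(C)C(=O)/C(=C(O)/C=C/c2ccccc2OC)C(=O)C1(C)C`). Compound 1 gives < 4 ug/mL as a limit too. Compound 2 gives < 4 ug/mL as a limit as well. All three therefore stand at one mark, namely the limit of < 4 ug/mL in this assay, at which 3 of the 3 values shown sit, and nothing finer can be said of compound 3.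

The next structure, compound 4 (`COC1=C(C)C(=O)/C(=C(O)/C=C/c2ccc(F)cc2)C(=O)C1(C)C`), has fluoro in place of hydroxy on an aromatic carbon and so turns 4-hydroxyphenyl into 4-fluorophenyl. The closest measured change is a step that the two limits leave unreadable from compound 1 to compound 3 with hydroxy in place of bromo on an aromatic carbon. Neither a step that the two limits leave unreadable from compound 1 to compound 2 nor a step that the two limits leave unreadable from compound 2 to compound 3 gives a size either. No measured size can therefore be carried over to the new change. In this assay no step beyond the scatter is expected and no direction can be named. The expected change is a step that the limit leaves unreadable from compound 3 to compound 4 as an estimate only. Compound 4 is estimated at 2 ug/mL with an expected range from 0.5 ug/mL to 5 ug/mL and another bare limit is quite likely.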

Compound 4, concentration for half-maximal effect: < 4 ug/mL
Compound 4: only a limit was reported; the forecaster's own chance of this, stated with the estimate: 85%; the middle value lies beyond the limit too.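

In this assay compound 4 gives < 4 ug/mL as a limit of the assay and not as a number. Its steps to compound 1, compound 2 and compound 3 therefore cannot be read, and all four compounds stand at one mark: the limit of < 4 ug/mL in this assay, at which 4 of the 4 values shown sit.

From the compounds shown here alone, what remains open is how far these four compounds differ from one another, if they differ at all, and whether swapping the groups on the aromatic ring changes the concentration needed.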